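The source may report more compounds than this note shows. Statements on the series, on what has been measured and on what is new or still open speak of the compounds shown alone.

Compound 1, `Cc1ccc2c(c1)CCN2S(=O)(=O)c1ccc(-c2cnc(C3CC3)o2)cc1`: 91.1%
Compound 2, `CS(=O)(=O)c1ccc2c(c1)CCN2S(=O)(=O)c1ccc(-c2cnc(C3CC3)o2)cc1`: 13%
Compound 3, `O=[N+]([O-])c1ccc2c(c1)CCN2S(=O)(=O)c1ccc(-c2cnc(C3CC3)o2)cc1`: 92.4%

All three share one core and differ only in one group on the fused benzene ring. In a functional assay on Jurkat cells (Homo sapiens) for inhibition, read by MTT assay, tested at 10 uM (a lower number here means less inhibition, a higher number more inhibition at the concentration tested (going by the name of the read-out)), compound 3 gives the highest of the three numbers, yet compound 1 sits within the scatter of it a number 1.3 percentage points higher from compound 1 to compound 3 (within the scatter), so the two cannot be told apart; compound 2 lies far lower a number 79.4 percentage points higher from compound 2 to compound 3 (beyond the scatter).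

Compound 4, `N#Cc1ccc2c(c1)CCN2S(=O)(=O)c1ccc(-c2cnc(C3CC3)o2)cc1`, is not yet measured. It differs from compound 3 in one place: cyano in place of nitro on an aromatic carbon.

Among the compounds with values here, two measured steps bear on this position. Swapping methyl for nitro changed little a number 1.3 percentage points higher from compound 1 to compound 3 (within the scatter), while swapping methyl for methylsulfonyl cut the number hard a number 78.1 percentage points lower from compound 1 to compound 2 (beyond the scatter). Within the data shown here, no measured step exchanges nitro for cyano, so the outcome is uncertain: at this spot some groups leave the number level and others bring it far lower. A moderate decrease is expected for compound 4 a number 22.4 percentage points lower from compound 3 to compound 4 (beyond the scatter), and its estimated value is 70%, spanning 20% to 95%.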

Compound 4, a percentage reported as inhibition, at one concentration (the size of the read-out at that concentration, not a potency): 15.8%
Compound 4: the middle estimate sits 54.2 percentage points above what was measured; the measured number lies below the stated range.
By their numbers in this assay, from the lowest: compounds 2 and 4 (each within the scatter of the next); then compounds 1 and 3 (each within the scatter of the next).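

At this position, cyano does not behave like nitro in this assay: exchanging one for the other brings the number far lower (a number 76.6 percentage points lower from compound 3 to compound 4 (beyond the scatter)), and cyano also falls well short of methyl (a number 75.3 percentage points lower from compound 1 to compound 4 (beyond the scatter)). Cyano instead cannot be told apart from methylsulfonyl (a number 2.8 percentage points higher from compound 2 to compound 4 (within the scatter)), so the four groups form two clear pairs, with methyl and nitro high and methylsulfonyl and cyano low. Nothing available explains why nitro and cyano part ways here.

From the compounds shown here alone, whether an amine, a methoxy group or a chlorine atom at this place would join the high pair or the low pair remains open. Going by these compounds, each number also comes from a single concentration, so how potency compares within each pair is unknown.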